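This account rests on a few compounds, and the source may have more. Where it says the series, first, only, none or still open, it means among the compounds named here.

Working notes on the series. For the measured compounds named here, in a functional assay on U-251 cells (Homo sapiens) for antiproliferative activity, read by MTT assay, with a stated time of 48 h (a higher number here means a weaker inhibitor, a lower number a stronger inhibitor), compound 1 `COc1cc(-c2cccc3nc(-c4ccccc4)oc23)cc(OC)c1OC` gives 3500 nM and compound 2 `COc1ccc(-c2nc3cccc(-c4cc(OC)c(OC)c(OC)c4)c3o2)cc1F` gives 1700 nM, the lower of the two numbers so far. Next is compound 3 `COc1cc(-c2cccc3nc(-c4cccc(F)c4)oc23)cc(OC)c1OC`, which has hydrogen in place of methoxy on an aromatic carbon, taking 3-fluoro-4-methoxyphenyl to 3-fluorophenyl: hydrogen in place of methoxy on an aromatic carbon. Going by the values given here, only one measured step bears on this change: a 2.1-fold lower number from compound 1 to compound 2 (0.31 log units; beyond the scatter). That modest step brought in the fluoro and methoxy groups together, so the data do not separate their shares. Compound 3 keeps the fluoro group and loses the methoxy, so a small move back up in this assay is expected, no larger than the measured step and possibly within the scatter. The expected step is a 1.4-fold higher number from compound 2 to compound 3 (0.15 log units; within the scatter). For compound 3 the estimated value is 2400 nM, with an expected range of 1200 nM to 4800 nM.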

Compound 3, half-maximal inhibitory concentration: 2900 nM
The estimate for compound 3 lay 1.2-fold (0.08 log units) below the measured number; the range from low to high includes it.
By their numbers in this assay, from the lowest: compounds 2, 3 and 1 (each within the scatter of the next, the first and the last beyond it).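

In this assay the earlier combined step can now be split at this position: fluoro alone gives a 1.2-fold lower number from compound 1 to compound 3 (0.08 log units; within the scatter), and the loss of the methoxy ortho to the fluoro group gives a 1.7-fold higher number from compound 2 to compound 3 (0.23 log units; within the scatter). Each part lies within the scatter, whereas the two changes together give a 2.1-fold lower number from compound 1 to compound 2 (0.31 log units; beyond the scatter), which lies beyond it, so neither group alone can be credited with a real change in this assay. Nothing at hand explains this result.

Still open, going by these compounds, is what the methoxy group does on the phenyl ring without the fluoro group. Also open, on these data alone, is whether an amine, a carboxylic acid or a longer chain such as ethoxy at this position would move the number beyond the scatter.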